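The source may report more compounds than this note shows. Statements on the series, on what has been measured and on what is new or still open speak of the compounds shown alone.

Measured so far in an ADME assay on LLC-PK1 cells (Sus scrofa) for permeability; a higher number here means that the compound crosses the layer faster, a lower number that the compound crosses the layer more slowly:
compound 1 `CCn1c(-c2cnc(C)nc2)nc2c(N[C@H]3CCN(C(=O)C4CCC4)C3)ncnc21` gives 32 10^-6 cm/s
compound 2 `CCn1c(-c2ccc(C(F)(F)F)nc2)nc2c(O[C@H]3CCN(C(=O)c4cocn4)C3)ncnc21` gives 29 10^-6 cm/s

In this assay compound 2 and compound 1 lie within the usual scatter of each other, so the two cannot be told apart. Compound 3 `CCn1c(-c2ccc(C(F)(F)F)nc2)nc2c(O[C@H]3CCN(C(=O)C4CCOC4)C3)ncnc21` is not yet measured. It differs from compound 2 by oxolan-3-yl in place of 1,3-oxazol-4-yl on a carbonyl carbon. Going by the values given here, no measured pair shows this change, so no step size can be read from the data. Expectation for this assay: the step from compound 2 to compound 3 is expected to be a 1.0-fold higher number from compound 2 to compound 3 (0.01 log units; within the scatter), no move beyond the scatter in either direction. Compound 3 is therefore expected at 30 10^-6 cm/s, within 17 10^-6 cm/s to 52 10^-6 cm/s.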

Compound 3, apparent permeability: 27 10^-6 cm/s
Compound 3: the middle estimate sits 1.1-fold (0.05 log units) above what was measured, within the range that was stated.
By their numbers in this assay, from the lowest: compounds 3, 2 and 1 (each within the scatter of the next).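

Going by these compounds alone, compound 2 and compound 3 give the first pair in this assay that differs in one place, and oxolan-3-yl in place of 1,3-oxazol-4-yl on a carbonyl carbon gives a step within the scatter (a 1.1-fold lower number from compound 2 to compound 3 (0.03 log units; within the scatter)). Here, a five-membered aromatic ring with 2 hetero atoms and a five-membered non-aromatic ring with 1 hetero atom cannot be told apart. No measurement on hand bears on this result.

On these data alone, whether an amine or a carboxylic acid on this carbonyl carbon would give a step beyond the scatter stays open. So does whether the same change behaves alike on the core of compound 1.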